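The source may hold more compounds than are shown below. What is called first, only, known or untested is meant among the compounds shown, and "the series" means these compounds.

Three compounds share one core and were tested in a functional assay on HCT-116 cells (Homo sapiens) for cytotoxicity, read by MTT assay, with a stated time of 48 h, in the presence of a further agent that is not named here; on this read-out lower numbers stand for an effect already at smaller amounts and higher numbers for an effect only at larger amounts of compound. Compound 1 `Cc1nn(C)c2nc(NNC(=O)Nc3cc(Cl)nc(Cl)c3)cc(-c3ccc(F)cc3)c12` gives 25200 nM, and compound 2 `Cn1ncc2c(-c3ccc(F)cc3)cc(NNC(=O)Nc3cc(F)cc(F)c3)nc21` gives 46200 nM. Compound 3 `CCCOc1cc(NC(=O)NNc2cc(-c3ccc(OC)cc3)c3cnn(C)c3n2)cc(Cl)n1` gives 33300 nM, the second highest of the three numbers; its gap to compound 1 is within the scatter, and so is its gap to compound 2. Going by the values given here, no two of the measured compounds differ in only one place, so no single step has been read. Compound 4 `CCCCOc1cc(NC(=O)NNc2cc(-c3ccc(OC)cc3)c3cnn(C)c3n2)cc(Cl)n1` differs from compound 3 in one way: methyl in place of hydrogen on a saturated chain carbon, three bonds along the chain from an oxygen on an aromatic ring. Since the three measured compounds sit within the scatter of one another and none of them probes this change, there is no basis for expecting a step beyond the scatter in this assay in either direction. The number expected for compound 4 is therefore 33000 nM, within 14000 nM to 75000 nM. The expected step from compound 3 to compound 4 is thus a 1.0-fold lower number from compound 3 to compound 4 (0.00 log units; within the scatter), essentially none.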

Compound 4, half-maximal effective concentration: 36500 nM
The estimate for compound 4 lay 1.1-fold (0.04 log units) below the measured number; measured number inside the range.
By their numbers in this assay, from the lowest: compounds 1, 3, 4 and 2 (each within the scatter of the next).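

This is the first step among these compounds that differs in only one place, so the chain on the oxygen can now be read directly. In this assay, the added methyl, three bonds along the chain from an oxygen on an aromatic ring, gives a 1.1-fold higher number from compound 3 to compound 4 (0.04 log units; within the scatter). At this position, then, going from propyl to butyl leaves the number within the scatter, and nothing shown bears on why.

From the compounds shown here alone, whether a longer chain, or an amine in place of the entering methyl, would carry the number beyond the scatter in this assay remains open. Also open, going by these compounds, is whether the same change would read alike in compounds that carry the other groups seen in compound 1 and compound 2, since this single step comes from one pair in one assay.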